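Chloro on the sulfonamide aryl across two cores

A few compounds are considered here, and "the series" means these few. Any claim that something is new, unique, unknown or untested is made for them only; others in the source may bear on it.

Measured compounds in a functional assay on thoracic aorta for antagonist activity at thromboxane A2 receptor (Rattus norvegicus); a higher number here means a weaker inhibitor, a lower number a stronger inhibitor:
compound 1, `CC(C)c1ccc2c(CCCCCS(=O)(=O)Nc3ccccc3)cc(C(=O)O)c-2cc1`, gives 1500 nM
compound 2, `CC(C)c1ccc2c(CCCCCS(=O)(=O)Nc3ccc(Cl)cc3)cc(C(=O)O)c-2cc1`, gives 1700 nM
compound 3, `CC(C)c1ccc2c(CCCS(=O)(=O)Nc3ccccc3)cc(S(=O)(=O)O)c-2cc1`, gives 8700 nM

Compound 1 and compound 2 share a core and differ in one place:
chloro in place of hydrogen on an aromatic carbon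
The step this makes is a 1.1-fold higher number from compound 1 to compound 2 (0.05 log units; within the scatter), so the two numbers cannot be ordered.

Compound 3 stands on a different core; the difference between the two cores is not broken down here. Its number is the highest of the three: compound 3 is beyond the scatter from compound 2 and from compound 1 alike, so the core of compound 3 sits on the weaker side in this assay.

Compound 4, `CC(C)c1ccc2c(CCCS(=O)(=O)Nc3ccc(Cl)cc3)cc(S(=O)(=O)O)c-2cc1`, has not been measured. It differs from compound 3 thus:
chloro in place of hydrogen on an aromatic carbon
The place is described in the same words as for the change from compound 1 to compound 2, so this is the same change, made on the core of compound 3.

Going by the values given here, the only guide is the measured pair: because a 1.1-fold higher number from compound 1 to compound 2 (0.05 log units; within the scatter) stays within the scatter, the same change on compound 3 is expected to leave the number near that of compound 3. For compound 4 the estimated value in this assay is 9500 nM, expected to lie between 4500 nM and 20000 nM. The expected step is a 1.1-fold higher number from compound 3 to compound 4 (0.04 log units; within the scatter), within the scatter; whether the second core answers the change differently is not known.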

Compound 4, half-maximal inhibitory concentration: 860 nM
Beside the measured number, compound 4's estimate is 11-fold (1.04 log units) above it, and the stated range ends above it.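

In this assay, phenyl to 4-chlorophenyl on the core of compound 3 gives a 10-fold lower number from compound 3 to compound 4 (1.01 log units; beyond the scatter), a large step that makes compound 4 the stronger of that pair. The same change therefore does not carry over unchanged from one core to the other, and a flat result on the core of compound 1 gives no safe guide to the result on the core of compound 3: the same change on two cores in this assay, a 1.1-fold higher number (0.05 log units; within the scatter) from compound 1 to compound 2 and a 10-fold lower number (1.01 log units; beyond the scatter) from compound 3 to compound 4, 11-fold (1.06 log units) apart, beyond the scatter of two such steps This does not show which part of the core goes with the difference, since the two cores differ both in the acid group, a carboxylic acid on one and a sulfonic acid on the other, and in the length of the chain, and it rests on a single pair for each core, so no rule for the series follows from it.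

Still open, as far as these compounds go, is which of these two differences matters, which a carboxylic acid on the shorter chain or a sulfonic acid on the longer chain would help to separate. Also open, from the compounds shown here alone, is whether the large step belongs to chloro alone or would also appear with fluoro, bromo or methoxy at the same place on the ring of compound 3.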